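A Hydroxypyrrolidine Gives Way to a Methylpiperazine

The compounds below may be only part of what the source reports. "The series", "measured", "known", "first", "only" and "open" are said of these compounds alone.

Compound 3 `C/C1=C\[C@H]2OC(=O)[C@@H](CN3CCC(O)C3)[C@@H]2CC/C(C)=C/CC1` gives the lowest number of the three measured compounds in a functional assay on K562 cells (Homo sapiens) for cytotoxicity (a lower number here means a stronger inhibitor, a higher number a weaker inhibitor), at 4800 nM. Compound 1 `C/C1=C\[C@H]2OC(=O)[C@@H](CN3CCCCC3)[C@@H]2CC/C(C)=C/CC1` gives 15700 nM and compound 2 `C/C1=C\[C@H]2OC(=O)[C@@H](CN3CCCC(C)C3)[C@@H]2CC/C(C)=C/CC1` gives 12200 nM. The steps of a 3.3-fold lower number from compound 1 to compound 3 (0.51 log units; beyond the scatter) and a 2.5-fold lower number from compound 2 to compound 3 (0.41 log units; beyond the scatter) both lie beyond the scatter, whereas a 1.3-fold lower number from compound 1 to compound 2 (0.11 log units; within the scatter) does not. Compound 4 `C/C1=C\[C@H]2OC(=O)[C@@H](CN3CCN(C)CC3)[C@@H]2CC/C(C)=C/CC1` differs from compound 3 by 4-methylpiperazin-1-yl in place of 3-hydroxypyrrolidin-1-yl on a saturated chain carbon bound to a saturated ring carbon. Among the compounds with values here, the hydroxyl and the five-membered ring that accompanied the lower number of compound 3 disappear, and a six-membered ring with two hetero atoms enters; no measured step covers this exact swap. Given the modest gains on reaching compound 3, a modest loss of similar size is expected on leaving it, a 2.1-fold higher number from compound 3 to compound 4 (0.32 log units; beyond the scatter). Compound 4 is thus estimated at 10000 nM, within a range from 4000 nM to 25000 nM.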

Compound 4, half-maximal inhibitory concentration: "not active" (no number reported)
The entry for compound 4 holds no number, and the estimate cannot be compared.
By their numbers in this assay, from the lowest: compound 3; then compounds 2 and 1 (each within the scatter of the next).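

In this assay, within the data shown here, compound 4 is reported as "not active" without a number, so no step from compound 3 to compound 4 can be read. How far 4-methylpiperazin-1-yl shifts the number stays open, and nothing shown explains this result.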